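A Fluoro Step Repeated Across Two Related Cores

The source may hold more compounds than are shown below. What is called first, only, known or untested is meant among the compounds shown, and "the series" means these compounds.

Compound 1, with the structure `CC(=O)c1cc(-c2ccccc2)cc2cc(-c3ccccc3)[nH]c12`, was tested in a functional assay on MCF7 cells (Homo sapiens) for cytotoxicity, read by MTT assay, with a stated time of 2 days, tested at 0.1 uM (on this read-out lower numbers stand for a stronger effect and higher numbers for a weaker effect at the one concentration tested), where compound 1 gives 99.3%. Compound 2, `CC(=O)c1cc(-c2ccc(F)cc2)cc2cc(-c3ccccc3)[nH]c12`, carries fluoro in place of hydrogen on an aromatic carbon relative to compound 1, and in this assay compound 2 gives 98.3%. The step of a number 1 percentage points lower from compound 1 to compound 2 (within the scatter) is small, so the two values show no real difference at this concentration.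

Compound 3, `CC(=O)c1cc(/C=C/c2ccccc2)cc2cc(-c3ccc(F)cc3)[nH]c12`, belongs to a second core; how its core differs from that of compound 1 is not broken down here. In this assay compound 3 gives 98.4%, a value that sits among those of compound 1 and compound 2 without being distinguished from either.

Compound 4, `CC(=O)c1cc(/C=C/c2ccc(F)cc2)cc2cc(-c3ccc(F)cc3)[nH]c12`, has not yet been measured. It differs from compound 3 by fluoro in place of hydrogen on an aromatic carbon, and its place is described in exactly the same words as the change from compound 1 to compound 2, so this is the same change made on a second core. Among the measured compounds shown here, the only precedent is the step of a number 1 percentage points lower from compound 1 to compound 2 (within the scatter), which lay within the scatter. On that basis the step from compound 3 to compound 4 in this assay is expected to be a number 0.9 percentage points lower from compound 3 to compound 4 (within the scatter), because a number 1 percentage points lower from compound 1 to compound 2 (within the scatter) gave no measurable shift. Compound 4 is therefore estimated to give 97.5%, with a likely range from 90% to 103%.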

Compound 4, a percentage reported as activity, at one concentration (the size of the read-out at that concentration, not a potency): 98.8%
Estimate against measurement, compound 4: 1.3 percentage points below; measured number inside the range.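

In this assay the fluoro change on the second core gives a number 0.4 percentage points higher from compound 3 to compound 4 (within the scatter), so replacing hydrogen with fluoro on an aromatic carbon, para to a large group, leaves no readable mark on the 2-phenylethenyl compound. Set beside the same change on the core of compound 1, the two steps do not differ, and on these two cores the change carries over as the absence of a measurable shift: the same change on two cores in this assay, a number 1 percentage points lower (within the scatter) from compound 1 to compound 2 and a number 0.4 percentage points higher (within the scatter) from compound 3 to compound 4, 1.4 percentage points apart, within the scatter of two such steps

This does not show that fluoro has any particular effect on cytotoxicity, since neither step can be told from the scatter and each rests on a single concentration, so the pair of steps gives neither a direction nor a potency, and two cores are too few to speak for the series as a whole.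

The compounds shown leave open how a chlorine atom, a methoxy group, an amine or a carboxylic acid would read in this assay if placed where the fluoro stands. They also leave open whether the two steps would still agree at a higher concentration, where a difference between the compounds might become readable.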